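Series notes: sulfonyl aryl change on compound 1

This account rests on a few compounds, and the source may have more. Where it says the series, first, only, none or still open, it means among the compounds named here.

Compound 1 `O=S(=O)(c1ccc(F)c(F)c1)c1cnc2cc(F)ccc2c1-c1cccc(Cl)c1` is the lowest of the three measured compounds in an ADME assay on microsomes from liver (Homo sapiens) for metabolic stability, tested at 2.5 uM (a lower number here means slower removal, a higher number faster removal of the compound), where compound 1 gives 0.38 mL/min. Compound 2 `COc1ccc(-c2c(S(=O)(=O)c3ccc(F)c(F)c3)cnc3cc(F)ccc23)cc1` gives 1.1 mL/min in this assay, a change of a 2.9-fold higher number from compound 1 to compound 2 (0.46 log units; beyond the scatter), and compound 3 `COc1cccc(-c2c(S(=O)(=O)c3ccc(F)c(F)c3)cnc3cc(F)ccc23)c1` gives 1.77 mL/min, a change of a 4.7-fold higher number from compound 1 to compound 3 (0.67 log units; beyond the scatter); between them the step is a 1.6-fold higher number from compound 2 to compound 3 (0.21 log units; within the scatter). All three of those steps alter the aryl group on the core, not the sulfonyl aryl.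

Compound 4 `Cc1ccc(S(=O)(=O)c2cnc3cc(F)ccc3c2-c2cccc(Cl)c2)cc1F` differs from compound 1 on the sulfonyl side: methyl in place of fluoro on an aromatic carbon, read one bond further out as 3,4-difluorophenyl to 3-fluoro-4-methylphenyl. Among the compounds with values here, no measured step touches this part of the structure, so none bears directly on it; the measured steps show only that changes on the other aryl group moved this assay by modest amounts, upward from compound 1 in both cases. Within the data shown here, with no direct precedent, the expectation for compound 4 is a step of a 1.6-fold higher number from compound 1 to compound 4 (0.20 log units; within the scatter), that is no clear change beyond the scatter, leaning upward. Compound 4 is therefore estimated at 0.6 mL/min, with a range from 0.3 mL/min to 1.3 mL/min.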

Compound 4, intrinsic clearance in a liver preparation (reported as CLH), per the amount of preparation that the assay uses: 2.13 mL/min
Compound 4: the middle estimate sits 3.6-fold (0.55 log units) below what was measured; the whole stated range lies below it.
By their numbers in this assay, from the lowest: compound 1; then compounds 2, 3 and 4 (each within the scatter of the next).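

Within the data shown here, the sulfonyl aryl group, which no earlier step touched, is not a silent position in this assay: methyl in place of fluoro, on the aromatic carbon para to a large group and ortho to a fluoro group, gives a 5.6-fold higher number from compound 1 to compound 4 (0.75 log units; beyond the scatter). This exchange swaps one heavy atom for one, with no change in rings, hydrogen-bond donors or acceptors, or net charge, yet the step lies beyond the scatter. Nothing available gives a reason for this rise.

Only one replacement at this carbon is shown, so it remains open how a nitrile, an amine or a longer chain such as ethyl would read there. Also open, from the compounds shown here alone, is whether the same change would move compound 2 or compound 3 in the same direction.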